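A few compounds are considered here, and "the series" means these few. Any claim that something is new, unique, unknown or untested is made for them only; others in the source may bear on it.

In an assay on isolated protein for displacement of a labelled ligand from metabotropic glutamate receptor 5 (Homo sapiens), with a stated time of 60 min, tested at 1 uM (on this read-out lower numbers stand for less inhibition and higher numbers for more inhibition at the one concentration tested (going by the name of the read-out)), compound 2, whose structure is `Cc1ccc(S(=O)(=O)c2cnc3c(F)cccc3c2N2CCC(C)CC2)cc1F`, gives 93%, the highest of the three numbers recorded. Compound 3, `Cc1ccc2ncc(S(=O)(=O)c3cccc(C#N)c3)c(N3CCC(C)CC3)c2c1`, gives 52% in this assay, a reading well beyond the usual scatter below compound 2. Compound 1, `COc1cccc(S(=O)(=O)c2cnc3ccc(OC)cc3c2N2CCC(C)CC2)c1`, gives 0% in this assay, the furthest below compound 2, also beyond the scatter. No pair among these three differs in a single place, so the numbers are simply taken as they stand.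

Compound 4, `CC1CCN(c2c(S(=O)(=O)c3ccccc3)cnc3c(F)cccc23)CC1`, has not yet been measured. Relative to compound 2 the change is phenyl in place of 3-fluoro-4-methylphenyl on a sulfonyl sulfur. The shared core of compound 2 is kept; only the aryl group on the sulfonyl sulfur is simplified. Without a measured single-point step to lean on, the expectation is a downward step from compound 2 to compound 4 in this assay of moderate size, a number 28 percentage points lower from compound 2 to compound 4 (beyond the scatter), probably beyond the scatter but leaving substantial inhibition. Compound 4 is therefore estimated to give 65% in this assay, within a range from 30% to 90%.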

Compound 4, a percentage reported as inhibition, at one concentration (the size of the read-out at that concentration, not a potency): 13%
Compound 4: middle estimate off by 52 percentage points, on the high side; measured number below the stated range.
By their numbers in this assay, from the lowest: compound 1; then compound 4; then compound 3; then compound 2.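

In this assay, among the compounds shown here, phenyl in place of 3-fluoro-4-methylphenyl on a sulfonyl sulfur gives a number 80 percentage points lower from compound 2 to compound 4 (beyond the scatter), the first step here that changes one place only. For the compounds shown here, with the shared core kept and the six-membered aromatic ring still present, the inhibition at the one tested concentration therefore depends strongly on the substituents of this aryl group, a link the earlier compounds could not isolate. No measurement bearing on the reason for this step is available.

The compounds shown leave open whether the fluorine, the methyl or both together account for the step, and how a 3-fluorophenyl or a 4-methylphenyl group alone would read on this core. They also leave open how a chlorine or a trifluoromethyl on this aryl ring would read.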